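The compounds below may be only part of what the source reports. "The series", "measured", "known", "first", "only" and "open" are said of these compounds alone.

Working notes on the series. All three measured compounds share one core and differ only in the aryl on its aromatic nitrogen: compound 1 `O=C(Nc1ccc(Oc2ccnc3[nH]ccc23)c(F)c1)c1cc2cccnc2n(-c2ccccc2)c1=O` carries a phenyl, compound 2 `O=C(Nc1ccc(Oc2ccnc3[nH]ccc23)c(F)c1)c1cc2cccnc2n(-c2ccc(Cl)cc2)c1=O` a 4-chlorophenyl and compound 3 `O=C(Nc1ccc(Oc2ccnc3[nH]ccc23)c(F)c1)c1cc2cccnc2n(-c2ccc(F)c(Cl)c2)c1=O` a 3-chloro-4-fluorophenyl. In a functional assay on HT-29 cells (Homo sapiens) for antiproliferative activity, read by MTT assay, with a stated time of 72 h (on this read-out lower numbers stand for stronger inhibition and higher numbers for weaker inhibition), compound 1 gives 160 nM. In this assay compound 2 gives 82 nM, the lowest of the three numbers, while compound 3 gives 310 nM. The step of a 2.0-fold lower number from compound 1 to compound 2 (0.29 log units; within the scatter) stays within the scatter, as does a 1.9-fold higher number from compound 1 to compound 3 (0.29 log units; within the scatter); only a 3.8-fold higher number from compound 2 to compound 3 (0.58 log units; beyond the scatter) goes beyond it, and modestly.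

Compound 4 `Cn1ccc2c(Oc3ccc(NC(=O)c4cc5cccnc5n(-c5ccc(Cl)cc5)c4=O)cc3F)ccnc21` keeps the 4-chlorophenyl of compound 2 and differs from it only by methyl in place of hydrogen on an aromatic nitrogen, the place being an aromatic nitrogen of a five-membered aromatic ring with one nitrogen, part of a fused system of two rings. Among the compounds with values here, none of the measured steps touches that part of the molecule; all of them vary the aryl on the aromatic nitrogen of the core, and two of the three stay within the scatter anyway. The measured compounds therefore give no direct guide for this change, and the working expectation is a step of a 1.3-fold higher number from compound 2 to compound 4 (0.13 log units; within the scatter) that does not go beyond the scatter. For compound 4 the estimated value in this assay is 110 nM, with a range from 40 nM to 320 nM.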

Compound 4, half-maximal inhibitory concentration: 220 nM
Compound 4: middle estimate off by 2.0-fold (0.30 log units), on the low side; the measured number falls inside the stated range.
By their numbers in this assay, from the lowest: compounds 2, 1, 4 and 3 (each within the scatter of the next, the first and the last beyond it).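

In this assay, methyl in place of hydrogen on an aromatic nitrogen of a five-membered aromatic ring with 1 nitrogen gives a 2.7-fold higher number from compound 2 to compound 4 (0.43 log units; beyond the scatter), a modest weakening. Within the data shown here, this is the first measured change at this position, and it shows that activity responds to this part of the molecule as well as to the aryl on the aromatic nitrogen of the shared core, where only the step between the 4-chlorophenyl and the 3-chloro-4-fluorophenyl goes beyond the scatter. No measurement shown here bears on why the methyl has this effect.

From the compounds shown here alone, the position rests on this single pair, so it remains open whether methyl gives a step of similar size with the phenyl of compound 1 or the 3-chloro-4-fluorophenyl of compound 3. Going by these compounds, it is also open how the number would respond to ethyl, a longer chain, or a chain ending in an amine or a carboxylic acid on the same nitrogen.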